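Pyridin-3-yl to 1H-imidazol-5-yl on the Sulfanyl Arm

The source may hold more compounds than are shown below. What is called first, only, known or untested is meant among the compounds shown, and "the series" means these compounds.

Compound 1 `N#Cc1c(N)nc(SCc2cccnc2)c(C#N)c1-c1ccc(OCC2CC2)cc1` was tested in an assay on CHO cells for displacement of a labelled ligand from adenosine receptor A3 (Homo sapiens), read by scintillation counting, with a stated time of 120 min, tested at 1 uM (on this read-out lower numbers stand for less inhibition and higher numbers for more inhibition at the one concentration tested (going by the name of the read-out)), and gave 19%. Compound 2 `CC(C)COc1ccc(-c2c(C#N)c(N)nc(SCC(N)=O)c2C#N)cc1` gave 9% in this assay, a number that lies within the scatter of that of compound 1, so both sit low on this read-out. Compound 3 `N#Cc1c(N)nc(SCc2cnc[nH]2)c(C#N)c1-c1ccc(OCC2CC2)cc1` has not yet been measured in this assay. It differs from compound 1 in one place: 1H-imidazol-5-yl in place of pyridin-3-yl on a saturated chain carbon bound to a sulfur. Among the measured compounds shown here, no measured pair shows this change. Compound 3 is expected to move little, a number 4 percentage points lower from compound 1 to compound 3 (within the scatter), no step beyond the scatter. The estimate for compound 3 is 15%, with a range from 0% to 35%.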

Compound 3, a percentage reported as inhibition, at one concentration (the size of the read-out at that concentration, not a potency): 1%
Compound 3: middle estimate off by 14 percentage points, on the high side, within the range that was stated.
By their numbers in this assay, from the lowest: compounds 3, 2 and 1 (each within the scatter of the next, the first and the last beyond it).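

On the saturated chain carbon bound to a sulfur, the ring is not interchangeable in this assay: 1H-imidazol-5-yl in place of pyridin-3-yl gives a number 18 percentage points lower from compound 1 to compound 3 (beyond the scatter) on an otherwise unchanged core. The change replaces a six-membered aromatic ring with a five-membered one and brings in a hydrogen-bond donor, and this single pair cannot separate these differences. Nothing available accounts for the drop. Going by these compounds, whether a phenyl ring, a carboxylic acid or a longer chain at this place would raise or lower the number remains open. So does whether the step recurs with the isobutoxy group of compound 2 in place of the cyclopropylmethoxy group.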